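The compounds below may be only part of what the source reports. "The series", "measured", "known", "first", "only" and "open" are said of these compounds alone.

Measured so far in a functional assay for inhibition of sodium/hydrogen exchanger (Oryctolagus cuniculus); a lower number here means a stronger inhibitor, a higher number a weaker inhibitor:

compound 1, `CCc1cc(C)c(C(=O)N=C(N)N)cc1S(C)(=O)=O`, 4.8 nM
compound 2, `CCCc1cc(C)c(C(=O)N=C(N)N)cc1S(C)(=O)=O`, 5.7 nM
compound 3, `Cc1cc(Sc2ccccc2Cl)c(S(C)(=O)=O)cc1C(=O)N=C(N)N`, 14 nM

Compound 3 gives the highest number of the three; compound 2 lies nearest, a 2.5-fold higher number from compound 2 to compound 3 (0.39 log units; beyond the scatter), and compound 1 furthest, a 2.9-fold higher number from compound 1 to compound 3 (0.46 log units; beyond the scatter). Compound 1 and compound 2 sit within the scatter of each other, a 1.2-fold higher number from compound 1 to compound 2 (0.07 log units; within the scatter).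

Compound 4, `Cc1cc(Sc2ccc(Cl)cc2)c(S(C)(=O)=O)cc1C(=O)N=C(N)N`, is not yet measured. Its difference from compound 3 is 4-chlorophenyl in place of 2-chlorophenyl on a sulfur. Within the data shown here, no measured pair varies the placing of the chlorine on the phenyl; the two steps that involve this phenyl group, from compound 1 and from compound 2 to compound 3, each swap an alkyl chain for the whole (2-chlorophenyl)sulfanyl group and were modest in size, so they bear on the change only loosely. There is thus no basis for a directional expectation, and the step to compound 4 is expected to stay within the scatter, no change at the digits printed from compound 3 to compound 4 (within the scatter). For compound 4 the expected value in this assay is 14 nM, with a range from 5 nM to 40 nM.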

Compound 4, half-maximal inhibitory concentration: 19 nM
Compound 4: middle estimate off by 1.4-fold (0.13 log units), on the low side, within the range that was stated.
By their numbers in this assay, from the lowest: compounds 1 and 2 (each within the scatter of the next); then compounds 3 and 4 (each within the scatter of the next).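

In this assay, among these compounds, the first pair to vary the placing of the chlorine gives a 1.4-fold higher number from compound 3 to compound 4 (0.13 log units; within the scatter) on going to 4-chlorophenyl in place of 2-chlorophenyl on the sulfur, so the two placings cannot be told apart here. Replacing an alkyl chain with (4-chlorophenyl)sulfanyl gives a 3.3-fold higher number from compound 2 to compound 4 (0.52 log units; beyond the scatter) for the propyl compound and a 4.0-fold higher number from compound 1 to compound 4 (0.60 log units; beyond the scatter) for the ethyl compound, modest steps in the same direction as those to compound 3. No measurement available here accounts for any of these steps.

Still open is whether the chlorine matters at all, which an unsubstituted phenyl on the sulfur would test, and whether 3-chlorophenyl would match the two placings shown. A phenoxy group or an amine in place of the whole (4-chlorophenyl)sulfanyl group would test how much depends on the sulfur.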